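Replacing methoxy with bromo in compound 2

The source may report more compounds than this note shows. Statements on the series, on what has been measured and on what is new or still open speak of the compounds shown alone.

Measured in a functional assay on MCF7 cells (Homo sapiens) for antiproliferative activity, read by MTT assay, with a stated time of 48 h; a lower number here means a stronger inhibitor, a higher number a weaker inhibitor:
compound 1 `O=C(/C=C/c1ccc(C(F)(F)F)cc1)Nc1nnc(-c2ccc(Br)cc2)s1`: 1.58 ug/mL
compound 2 `COc1ccc(-c2nnc(NC(=O)/C=C/c3ccc(F)cc3)s2)cc1`: 0.85 ug/mL

The number for compound 2 lies within the usual scatter of the number for compound 1, so the two cannot be separated. Compound 3 `O=C(/C=C/c1ccc(F)cc1)Nc1nnc(-c2ccc(Br)cc2)s1` has bromo in place of methoxy on an aromatic carbon, para to a large group: bromo in place of methoxy on an aromatic carbon. Within the data shown here, no measured pair isolates this change. Compound 1, which also carries the 4-bromophenyl, gives 1.58 ug/mL, so a small rise, not beyond the scatter, is expected in this assay. The estimated step is a 1.4-fold higher number from compound 2 to compound 3 (0.15 log units; within the scatter). Compound 3 is expected at 1.2 ug/mL, within a range of 0.5 ug/mL to 2.9 ug/mL.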

Compound 3, half-maximal inhibitory concentration: 1.49 ug/mL
The estimate for compound 3 lay 1.2-fold (0.09 log units) below the measured number; measured number inside the range.
By their numbers in this assay, from the lowest: compounds 2, 3 and 1 (each within the scatter of the next).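

In this assay, the change from 4-methoxyphenyl to 4-bromophenyl now rests on a measured pair: a 1.8-fold higher number from compound 2 to compound 3 (0.24 log units; within the scatter). This step lies within the scatter, so the two groups cannot be separated at this position on this evidence. Fluoro in place of trifluoromethyl on an aromatic carbon also gives a step within the scatter, a 1.1-fold lower number from compound 1 to compound 3 (0.03 log units; within the scatter), and no available measurement explains either step. The compounds shown leave open whether an amine or a carboxylic acid in place of bromo or methoxy would give a number beyond the scatter of these three.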